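The compounds below may be only part of what the source reports. "The series", "measured", "known", "first", "only" and "open" are said of these compounds alone.

Compound 1, `N#Cc1cccc(S(=O)(=O)c2cnc3cc(F)ccc3c2-c2cccc(Cl)c2)c1`: 0.99 mL/min
Compound 2, `COc1ccc(S(=O)(=O)c2cnc3cc(F)ccc3c2-c2cccc(F)c2)cc1Cl`: 2.08 mL/min

Two compounds have been run in an ADME assay on microsomes from liver (Homo sapiens) for metabolic stability, tested at 2.5 uM; on this read-out higher numbers stand for fast clearance and lower numbers for slow clearance. Compound 1 gives 0.99 mL/min, and compound 2 gives 2.08 mL/min. Compound 2 therefore holds the higher of the two numbers; its nearest neighbour is compound 1, and that gap lies beyond the scatter, with compound 1 cleared more slowly. Compound 3, `COc1ccc(S(=O)(=O)c2cnc3cc(F)ccc3c2-c2cccc(Cl)c2)cc1Cl`, has not yet been measured in this assay. It differs from compound 2 in one place: chloro in place of fluoro on an aromatic carbon. Within the data shown here, no measured pair shows exactly this step; compound 1 also carries a 3-chlorophenyl, but it differs from compound 2 elsewhere as well, so its value alone cannot fix the size. A small step is expected, a 1.2-fold lower number from compound 2 to compound 3 (0.06 log units; within the scatter), most likely not beyond the scatter. For compound 3 the expected value is 1.8 mL/min, with a range from 0.9 mL/min to 3.6 mL/min.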

Compound 3, intrinsic clearance in a liver preparation (reported as CLH), per the amount of preparation that the assay uses: 1.19 mL/min
Beside the measured number, compound 3's estimate is 1.5-fold (0.18 log units) above it, and the stated range covers the measured number.
By their numbers in this assay, from the lowest: compounds 1, 3 and 2 (each within the scatter of the next, the first and the last beyond it).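

In this assay, 3-chlorophenyl in place of 3-fluorophenyl gives a 1.7-fold lower number from compound 2 to compound 3 (0.24 log units; within the scatter), so this read-out does not separate the two halogens at this position. At the sulfonyl sulfur, 3-chloro-4-methoxyphenyl in place of 3-cyanophenyl gives a 1.2-fold higher number from compound 1 to compound 3 (0.08 log units; within the scatter), which also stays within the usual scatter, so compound 3 links compound 1 and compound 2 through two single changes, neither of which alone lies beyond it. Nothing available here explains these results.

On these data alone, what a trifluoromethyl group, an amine or a carboxylic acid on that aromatic carbon would do to clearance remains open. As far as these compounds go, it is also open whether the change at the sulfonyl sulfur would read the same with 3-fluorophenyl in place of 3-chlorophenyl.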